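Methoxy on the anilino group: notes toward compound 3

The source may report more compounds than this note shows. Statements on the series, on what has been measured and on what is new or still open speak of the compounds shown alone.

Compound 1 `FC(F)(F)c1ccc(CSc2nc(N3CCCCC3)c3ccccc3n2)cc1` and compound 2 `FC(F)(F)c1ccc(CSc2nc(Nc3ccccc3)c3ccccc3n2)cc1` share the same core and differ only in the group attached to one aromatic carbon of it. In a functional assay on PC-3 cells (Homo sapiens) for cytotoxicity, read by MTT assay, with a stated time of 72 h (on this read-out higher numbers stand for weaker inhibition and lower numbers for stronger inhibition), compound 1 gives 25500 nM, and in this assay compound 2 gives 20000 nM. Within the data shown here, the step of a 1.3-fold lower number from compound 1 to compound 2 (0.11 log units; within the scatter) leaves the two compounds within the scatter of one another, so compound 2 holds the lower of the two numbers measured so far without standing apart from compound 1.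

Compound 3 `COc1ccccc1Nc1nc(SCc2ccc(C(F)(F)F)cc2)nc2ccccc12` has not yet been measured. It differs from compound 2 by methoxy in place of hydrogen on an aromatic carbon. Among the measured compounds shown here, no measured step touches this part of the molecule: the only step recorded exchanges the group on the core itself and stays within the scatter. There is therefore no basis for expecting a shift beyond the scatter in this assay, in either direction.

Compound 3 is thus estimated at 18000 nM in this assay, with an expected range from 7000 nM to 45000 nM. The expected step of a 1.1-fold lower number from compound 2 to compound 3 (0.05 log units; within the scatter) is estimated to remain within the scatter.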

Compound 3, half-maximal inhibitory concentration: 14100 nM
The estimate for compound 3 lay 1.3-fold (0.11 log units) above the measured number, within the range that was stated.
By their numbers in this assay, from the lowest: compounds 3, 2 and 1 (each within the scatter of the next).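

Among these compounds, the anilino ring is touched here for the first time: methoxy in place of hydrogen, on an aromatic carbon ortho to a large group, gives a 1.4-fold lower number from compound 2 to compound 3 (0.15 log units; within the scatter) in this assay, so this position takes methoxy without a shift beyond the scatter. Among the compounds shown here, the exchange of piperidin-1-yl for (2-methoxyphenyl)amino, which combines this substitution with the earlier change on the core, gives a 1.8-fold lower number from compound 1 to compound 3 (0.26 log units; within the scatter), so even the widest step so far stays inside the scatter in this assay. Nothing available explains these numbers, and no reason for them can be given.

The compounds shown leave open whether this carbon of the anilino ring responds at all, since a single small substituent cannot separate a flat position from one that simply has not yet been challenged by a carboxylic acid, an amine or a longer chain such as butoxy. The trifluoromethyl group also remains the same in all three compounds, so its contribution to numbers of this size cannot be read from them.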